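Swapping a chlorophenyl for a pyridine in a cytotoxicity series

The source may report more compounds than this note shows. Statements on the series, on what has been measured and on what is new or still open speak of the compounds shown alone.

All four compounds share one core, a thymine-like ring joined through a piperidine to a benzyl group that carries an aryl ether. They were tested in an ADME assay on MRC5 cells (Homo sapiens) for cytotoxicity, read by fluorescence and resazurin assay, with a stated time of 3 days; on this read-out higher numbers stand for weaker inhibition and lower numbers for stronger inhibition. Within the data shown here, compound 2 `Cc1cn(C2CCN(Cc3cccc(Oc4ccc(Cl)cc4)c3)CC2)c(=O)[nH]c1=O` is the only member with a plain number: in this assay compound 2 gives 25100 nM. From the compounds shown here alone, compound 3 `Cc1cn(C2CCN(Cc3ccnc(Oc4cccc(Cl)c4)c3)CC2)c(=O)[nH]c1=O` reaches only a limit of the assay, > 64000 nM, so its true value is unknown. Compound 1 `Cc1cn(C2CCN(Cc3cccc(Oc4cc(C(F)(F)F)cc(C(F)(F)F)c4)c3)CC2)c(=O)[nH]c1=O` has no result in this assay at all, "not determined" (no result reported). Among the measured compounds shown here, one of the values therefore sits at the limit of > 64000 nM in this assay, at which 1 of the 3 values shown sits, the other is the single measured number.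

Compound 4 `Cc1cn(C2CCN(Cc3cccc(Oc4ccccn4)c3)CC2)c(=O)[nH]c1=O` is not yet measured. It differs from compound 2 by pyridin-2-yl in place of 4-chlorophenyl on an oxygen on an aromatic ring. For the measured compounds named here, no pair of measured compounds differs in only one place, so no measured step guides this change; an expected step of a 1.6-fold higher number from compound 2 to compound 4 (0.20 log units; within the scatter) toward weaker inhibition is modest and may lie within the usual scatter. Compound 4 is estimated at 40000 nM, with a range from 18000 nM to 64000 nM, and a fair chance that only a limit is reported.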

Compound 4, half-maximal inhibitory concentration: > 64000 nM
Compound 4: only a limit was reported (the forecaster's own chance of this, stated with the estimate: 40%); middle value at least 1.6-fold (0.20 log units) away from the limit.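

Putting pyridin-2-yl in place of 4-chlorophenyl on an oxygen on an aromatic ring gives an at least 2.5-fold higher number from compound 2 to compound 4 (0.40 log units; beyond the scatter), the only step among the compounds shown that changes one place alone. It shows that the group on this oxygen can shift the result in this assay, here toward weaker inhibition. The true size of the shift stays unknown, since the value for compound 4 is a limit, and the set now gathers at that ceiling: the limit of > 64000 nM in this assay, at which 2 of the 4 values shown sit.

The compounds shown leave open whether losing the chlorine or gaining the ring nitrogen carries the step. A plain phenyl on the same oxygen would separate the two, while a 4-methoxyphenyl would show whether another group in the place of the chlorine behaves like it.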